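Swapping a Difluoropiperidine Amide for a Tetrahydroisoquinoline

This account rests on a few compounds, and the source may have more. Where it says the series, first, only, none or still open, it means among the compounds named here.

Compound 1 `C[C@@H](C(=O)N1CC2CC2C1)N1CCN(S(=O)(=O)c2ccc(C(C)(C)C)cc2)CC1`: in an ADME assay on HepG2 cells (Homo sapiens) for inhibition, with a stated time of 48 h (a higher number here means that more compound is needed for the effect, a lower number that less compound is needed), compound 1 reaches only the assay limit, > 40000 nM.
Compound 2 `CC(C(=O)N1CCC(F)(F)CC1)N1CCN(S(=O)(=O)c2ccc(C(C)(C)C)cc2)CC1`: in this assay compound 2 likewise reaches only the assay limit, > 40000 nM.

Among the compounds with values here, compound 2 therefore stands at a limit rather than at a number, and the one other value shown sits at the same place, (the limit of > 40000 nM in this assay, at which 2 of the 2 values shown sit). Compound 3 `CC(C(=O)N1CCc2ccccc2C1)N1CCN(S(=O)(=O)c2ccc(C(C)(C)C)cc2)CC1` carries 1,2,3,4-tetrahydroisoquinolin-2-yl in place of 4,4-difluoropiperidin-1-yl on a carbonyl carbon. Within the data shown here, no measured step connects the two compounds, so the expected step of a number no higher from compound 2 to compound 3 (the limit leaves the size open) is taken as none beyond the scatter, resting on (the limit of > 40000 nM in this assay, at which 2 of the 2 values shown sit). For compound 3 the estimate is 40000 nM, expected between 15000 nM and 100000 nM, most likely again reported only as a limit.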

Compound 3, half-maximal effective concentration: 29000 nM
Compound 3: middle estimate off by 1.4-fold (0.14 log units), on the high side; the measured number falls inside the stated range.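

Within the data shown here, compound 3 is the first compound here to give a measured number rather than a limit. Placing 1,2,3,4-tetrahydroisoquinolin-2-yl in place of 4,4-difluoropiperidin-1-yl on a carbonyl carbon gives an at least 1.3-fold lower number from compound 2 to compound 3 (0.13 log units; that floor lies within the scatter), so a real change is not shown and its true size stays open. Most values shown still sit at one limit: the limit of > 40000 nM in this assay, at which 2 of the 3 values shown sit.

As far as these compounds go, whether the aromatic ring of the 1,2,3,4-tetrahydroisoquinolin-2-yl group matters remains open. So does whether an open-chain amine such as diethylamino on this carbonyl carbon would give a clearly lower number.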